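This account rests on a few compounds, and the source may have more. Where it says the series, first, only, none or still open, it means among the compounds named here.

The measured compounds: compound 1 `COc1cccc2c1c(NS(=O)(=O)c1cccc(Cl)c1Cl)nn2C`, compound 2 `COc1cc2c(cc1NS(=O)(=O)c1cccc(Cl)c1Cl)[nH]c(=O)n2C`, compound 3 `COc1cc2c(cc1NS(=O)(=O)c1cccc(Cl)c1Cl)[nH]c(=O)n2C1COC1`. Not yet measured: compound 4 `COc1cc2c(cc1NS(=O)(=O)c1cccc(Cl)c1Cl)[nH]c(=O)n2C1CN(C(C)=O)C1`.

In an assay on cells (blood) for antagonist activity at C-C chemokine receptor type 4 (Homo sapiens), read by flow cytometry (a higher number here means weaker binding, a lower number tighter binding), compound 1 gives > 10000 nM, which is a limit of the assay and not a number. In this assay compound 2 gives > 10000 nM, again a limit. In this assay compound 3 gives > 10000 nM, also a limit. Compound 2 therefore stands only at a limit, with no number of its own, and the same holds for the other two values shown; the limit of > 10000 nM in this assay, at which 3 of the 3 values shown sit, is all that can be said of the set.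

The change from compound 2 to compound 4 is 1-acetylazetidin-3-yl in place of methyl on an aromatic nitrogen. Among the compounds with values here, the one measured step that bears on it, a step that the two limits leave unreadable from compound 2 to compound 3, is itself unreadable because of the two limits, so no size or direction can be taken from it. On that basis the step expected in this assay, a step that the limit leaves unreadable from compound 2 to compound 4, is none beyond the scatter, and most probably another limit. Compound 4 is therefore estimated at 20000 nM, within a range from 5000 nM to 100000 nM.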

Compound 4, dissociation constant: > 10000 nM
Compound 4 ended at the assay's limit; the forecaster's own chance of this, stated with the estimate: 85%; the middle value is on the limit's open side.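

In this assay, within the data shown here, compound 4 gives > 10000 nM, which is a limit and not a number, so no step from compound 2 or compound 3 to compound 4 can be read. The compounds shown leave open how any group on the aromatic nitrogen would affect binding, since none gives a measurable value: the limit of > 10000 nM in this assay, at which 4 of the 4 values shown sit.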